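Hydroxymethylphenyl in Place of Trifluoromethylphenyl in a Urea Series

The source may hold more compounds than are shown below. What is called first, only, known or untested is meant among the compounds shown, and "the series" means these compounds.

Compound 1 `Cc1ccc(C2(CNC(=O)Nc3c(C(C)C)cccc3C(C)C)CCCC2)cc1` and compound 2 `CC(C)c1cccc(C(C)C)c1NC(=O)NCC1(c2ccccc2C(F)(F)F)CCCC1` share a core and differ on a saturated ring carbon. In an assay on microsomes for inhibition of acyl-CoA:cholesterol acyltransferase (Oryctolagus cuniculus) (a lower number here means a stronger inhibitor, a higher number a weaker inhibitor), compound 1 gives 25 nM and compound 2 gives 18 nM. The step of a 1.4-fold lower number from compound 1 to compound 2 (0.14 log units; within the scatter) stays within the scatter. Compound 2 holds the lowest of the two numbers, with compound 1 nearest. Compound 3 `CC(C)c1cccc(C(C)C)c1NC(=O)NCC1(c2cccc(CO)c2)CCCC1` differs from compound 2 by 3-(hydroxymethyl)phenyl in place of 2-(trifluoromethyl)phenyl on a saturated ring carbon. Among the measured compounds shown here, only that one measured step bears on this change, and it was small, so at most a modest move toward a higher number is expected, a 2.2-fold higher number from compound 2 to compound 3 (0.35 log units; beyond the scatter). Compound 3 is estimated at 40 nM, ranging from 12 nM to 150 nM.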

Compound 3, half-maximal inhibitory concentration: 15 nM
The estimate for compound 3 lay 2.7-fold (0.43 log units) above the measured number, and the stated range covers the measured number.
By their numbers in this assay, from the lowest: compounds 3, 2 and 1 (each within the scatter of the next).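

In this assay the change gives a 1.2-fold lower number from compound 2 to compound 3 (0.08 log units; within the scatter) and, against the 4-methylphenyl group, a 1.7-fold lower number from compound 1 to compound 3 (0.22 log units; within the scatter). This position on the saturated ring carbon therefore takes 3-(hydroxymethyl)phenyl, with 1 hydrogen-bond donor and 1 hydrogen-bond acceptor, with no step beyond the scatter, which the two earlier compounds could not show. No evidence is available to explain this result. Still open, going by these compounds, is whether an amine or a carboxylic acid in place of the hydroxymethyl group would also leave the number within the scatter.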